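Fluoro for Chloro on the Core of Compound 2

This account rests on a few compounds, and the source may have more. Where it says the series, first, only, none or still open, it means among the compounds named here.

In a functional assay on HEK293 cells for agonist activity at Free fatty acid receptor 1 (Homo sapiens), read by fluorescence and calcium flux, with a stated time of 10 min (a higher number here means a larger maximal response, a lower number a smaller maximal response), compound 2 `CC#C[C@@H](CC(=O)O)c1ccc(OC[C@H]2COc3ccc(Cl)cc3O2)cc1` gives 86%, the second highest of the three values. Compound 1 `CC#CC(CC(=O)O)c1ccc(OCC2COc3ccc(Cl)cc3O2)cc1` gives 104%, and compound 3 `CC#C[C@@H](CC(=O)O)c1ccc(OC[C@@H]2COc3ccc(Cl)cc3O2)cc1` gives 65%. The measured steps are all matters of configuration: a number 18 percentage points lower from compound 1 to compound 2 (beyond the scatter), a number 39 percentage points lower from compound 1 to compound 3 (beyond the scatter) and a number 21 percentage points lower from compound 2 to compound 3 (beyond the scatter), the last resting on (the fact that compounds 2 and 3 differ only in the configuration as drawn). Compound 4 `CC#C[C@@H](CC(=O)O)c1ccc(OC[C@H]2COc3ccc(F)cc3O2)cc1` differs from compound 2 in one place: fluoro in place of chloro on an aromatic carbon. Among the compounds with values here, none of the measured steps exchanges one halogen for another, so they offer no guide to this change, and no step beyond the scatter is expected. The estimated step is no change at the digits printed from compound 2 to compound 4 (within the scatter). Compound 4 is expected to reach 86%, within 70% to 102%.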

Compound 4, largest response reached (Emax), in percent of the reference or control that the assay uses: 86%
Estimate against measurement, compound 4: no gap at the digits printed; low and high end bracket the measured number.
By their numbers in this assay, from the lowest: compound 3; then compounds 2 and 4 (each within the scatter of the next); then compound 1.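

In this assay, fluoro in place of chloro on an aromatic carbon gives no change at the digits printed from compound 2 to compound 4 (within the scatter), the first exchange of one halogen for another among these compounds, whose earlier steps were all of configuration. With the configuration of compound 2 held, the largest response therefore does not separate fluoro from chloro at this position. Nothing available bears on this halogen exchange.

From the compounds shown here alone, whether bromo, methyl or a nitrile at this place would keep that response remains open. So does whether fluoro would behave alike on the configuration of compound 3.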